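Pyrazolylamino substitution on the shared core: estimate for compound 4

A few compounds are considered here, and "the series" means these few. Any claim that something is new, unique, unknown or untested is made for them only; others in the source may bear on it.

Measured in an assay on isolated protein for inhibition of Leucine-rich repeat serine/threonine-protein kinase 2 variant G2019S (Homo sapiens), read by TR-FRET and LanthaScreen, with stated times of 50 min and 30 min, in the presence of a further agent that is not named here; on this read-out higher numbers stand for weaker inhibition and lower numbers for stronger inhibition:
compound 1 `C[C@@H]1CCCN1c1c(C#N)c2c(N)nc(Nc3cn[nH]c3)nc2n1C` gives 6 nM
compound 2 `Cc1nn(C2COC2)cc1Nc1nc(N)c2c(C#N)c(N3CCC[C@H]3C)n(C)c2n1` gives 25 nM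
compound 3 `C[C@@H]1CCCN1c1c(C#N)c2c(N)ncnc2n1C` gives 11 nM

Compound 3 stands second highest of the three numbers; compound 1 lies within the scatter of it, compound 2 beyond it. Compound 4 `C[C@@H]1CCCN1c1c(C#N)c2c(N)nc(Nc3cn(C)nc3Cl)nc2n1C` differs from compound 3 by (3-chloro-1-methyl-1H-pyrazol-4-yl)amino in place of hydrogen on an aromatic carbon. Among the measured compounds shown here, two measured steps bear on this change. Replacing the pyrazolylamino with hydrogen gave a 1.8-fold higher number from compound 1 to compound 3 (0.26 log units; within the scatter). Changing the substituents on the pyrazole gave a 4.2-fold higher number from compound 1 to compound 2 (0.62 log units; beyond the scatter), a modest shift. Compound 4 carries a substituted pyrazole, so a number near those of compound 1 and compound 2 is expected, and the step is expected to be a 1.6-fold higher number from compound 3 to compound 4 (0.21 log units; within the scatter), not beyond the scatter. The estimate for compound 4 in this assay is 18 nM, with a range from 7 nM to 45 nM.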

Compound 4, half-maximal inhibitory concentration: 21 nM
Estimate against measurement, compound 4: 1.2-fold (0.07 log units) below; the range from low to high includes it.
By their numbers in this assay, from the lowest: compounds 1, 3, 4 and 2 (each within the scatter of the next, the first and the last beyond it).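

At this aromatic carbon between two ring nitrogen atoms, the substituted pyrazolylamino group is not separated from hydrogen (a 1.9-fold higher number from compound 3 to compound 4 (0.28 log units; within the scatter)). The two substituted pyrazoles stay together (a 1.2-fold lower number from compound 2 to compound 4 (0.08 log units; within the scatter)), and the chloro-methyl pyrazole stands apart from the unsubstituted one (a 3.5-fold higher number from compound 1 to compound 4 (0.54 log units; beyond the scatter)), as the oxetanyl pyrazole also does. No measurement here accounts for these steps.

Still open, from the compounds shown here alone, is whether the chlorine or the methyl on the pyrazole accounts for the step from the unsubstituted pyrazole. Also open, going by these compounds, is how an aliphatic amine such as dimethylamino at this carbon would compare with hydrogen.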